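The compounds below may be only part of what the source reports. "The series", "measured", "known", "first", "only" and "open" are said of these compounds alone.

Measured compounds in a functional assay on K562 cells (Homo sapiens) for cytotoxicity, read by MTT assay, with a stated time of 48 h; a higher number here means a weaker inhibitor, a lower number a stronger inhibitor:

compound 1, `Cc1ccc(CN2CCN(C(=O)CN[C@H]3CCN(S(=O)(=O)Cc4ccccc4)C3)CC2)cc1`, gives 8200 nM
compound 2, `O=C(CN[C@H]1CCN(S(=O)(=O)Cc2ccccc2)C1)N1CCN(Cc2cccc(F)c2)CC1`, gives 13200 nM
compound 3, `O=C(CN[C@H]1CCN(S(=O)(=O)Cc2ccccc2)C1)N1CCN(Cc2c(Cl)cccc2Cl)CC1`, gives 28400 nM

Compound 2 sits second highest of the three numbers; its nearest neighbour is compound 1, with the step of a 1.6-fold higher number from compound 1 to compound 2 (0.21 log units; within the scatter) within the scatter, and its furthest is compound 3, with the step of a 2.2-fold higher number from compound 2 to compound 3 (0.33 log units; beyond the scatter) modest but beyond the scatter. The step of a 3.5-fold higher number from compound 1 to compound 3 (0.54 log units; beyond the scatter) is also modest.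

Compound 4, `COc1cc(CN2CCN(C(=O)CN[C@H]3CCN(S(=O)(=O)Cc4ccccc4)C3)CC2)cc(OC)c1OC`, differs from compound 2 at a single place: 3,4,5-trimethoxyphenyl in place of 3-fluorophenyl on a saturated chain carbon bound to an amine nitrogen in a ring. The measured steps all swap one aryl group for another at this same place; two of them, 1>2 and 2>3, touch the 3-fluorophenyl group that leaves, and none shows more than a modest shift, with the 2,6-dichlorophenyl group the only one moving beyond the scatter. Among the measured compounds shown here, no measured step introduces a 3,4,5-trimethoxyphenyl group, so the direction is open; the expectation is a step in this assay of about a 1.1-fold lower number from compound 2 to compound 4 (0.04 log units; within the scatter), roughly within the scatter. Compound 4 is therefore estimated at 12000 nM, between 5000 nM and 30000 nM.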

Compound 4, half-maximal inhibitory concentration: 93000 nM
Compound 4: the middle estimate sits 7.8-fold (0.89 log units) below what was measured, outside the stated range (above it).
By their numbers in this assay, from the lowest: compounds 1 and 2 (each within the scatter of the next); then compound 3; then compound 4.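

In this assay, among the compounds shown here, the place on a saturated chain carbon bound to an amine nitrogen in a ring tolerates less than the earlier aryl swaps suggested: the 3,4,5-trimethoxyphenyl group gives a 7.0-fold higher number from compound 2 to compound 4 (0.85 log units; beyond the scatter) and a 3.3-fold higher number from compound 3 to compound 4 (0.52 log units; beyond the scatter) and also an 11-fold higher number from compound 1 to compound 4 (1.05 log units; beyond the scatter) as the only large step in the set. Compound 4 is the weakest of the four, with its steps to all the others beyond the scatter, so this position can respond more strongly than the 2,6-dichlorophenyl group alone indicated. Nothing at hand accounts for this shift.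

The compounds shown leave open whether a single methoxy group on the phenyl ring would move the number as far as the three together. Also open, as far as these compounds go, is how a hydroxyl group or an amine in place of the methoxy groups would read in this assay.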